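Azetidinyl in place of dipropylamino on the shared core

The source may report more compounds than this note shows. Statements on the series, on what has been measured and on what is new or still open speak of the compounds shown alone.

The series shares one core and varies the group on a double-bonded ring carbon of the six-membered non-aromatic ring of carbon only, part of the fused system of four rings. Compound 1 `Cc1ccc(NC2=CC(=O)c3c(nc4n3[C@H]3OC[C@@H](O)[C@H]3OC4)C2=O)cc1C` carries (3,4-dimethylphenyl)amino there; in a functional assay on MCF7 cells (Homo sapiens) for inhibition, read by sulforhodamine B assay (a lower number here means a stronger inhibitor, a higher number a weaker inhibitor), compound 1 gives 4950 nM. Compound 2 `Cc1ccc(NC2=CC(=O)c3c(nc4n3[C@H]3OC[C@@H](O)[C@H]3OC4)C2=O)cc1` has hydrogen in place of methyl on an aromatic carbon. In this assay compound 2 gives > 4000 nM, a limit of the assay and not a number. Compound 3 `CCCN(CCC)C1=CC(=O)c2c(nc3n2[C@H]2OC[C@@H](O)[C@H]2OC3)C1=O` carries dipropylamino. In this assay compound 3 gives > 16000 nM, again a limit and not a number, so compound 3 stands at the weak end of the values shown. Of the steps, an at least 3.2-fold higher number from compound 1 to compound 3 (0.50 log units; beyond the scatter) is readable, whereas a step that the limit leaves unreadable from compound 1 to compound 2 and a step that the two limits leave unreadable from compound 2 to compound 3 are not.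

Compound 4 `O=C1C(N2CCC2)=CC(=O)c2c1nc1n2[C@H]2OC[C@@H](O)[C@H]2OC1` differs from compound 3 by azetidin-1-yl in place of dipropylamino on a double-bonded ring carbon. Within the data shown here, no measured step exchanges one dialkylamino group for another, so this change has no direct precedent. What is known is that both aryl amino groups left the number high and that dipropylamino gave only a limit. Compound 4 is therefore expected to stay close to compound 3, with a step that the limit leaves unreadable from compound 3 to compound 4 expected to fall within the scatter. Compound 4 is estimated at 20000 nM, between 5000 nM and 80000 nM, with a fair chance that only a limit is reported.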

Compound 4, half-maximal inhibitory concentration: > 16000 nM
Compound 4 was reported as a limit; the forecaster's own chance of this, stated with the estimate: 65%; the middle value does not contradict the limit.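

With azetidin-1-yl, a four-membered ring, in place of the open-chain dipropylamino on this double-bonded ring carbon, compound 4 again returns only a limit of the assay and not a number in this assay: the limit of > 16000 nM in this assay, at which 2 of the 4 values shown sit.

Among these compounds, the one readable new step is an at least 3.2-fold higher number from compound 1 to compound 4 (0.50 log units; beyond the scatter), which matches what the dipropylamino change already printed as an at least 3.2-fold higher number from compound 1 to compound 3 (0.50 log units; beyond the scatter), so two quite different amino groups without an aryl ring now sit on the weak side of the one aryl amino compound that has a number. That reading rests on compound 1 alone, since compound 2, which also carries an aryl amino group, is itself a limit, and the steps from compound 2 and from compound 3 to compound 4 cannot be read, both ends being limits.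

Going by these compounds, whether azetidin-1-yl and dipropylamino differ at all in this assay stays open, since neither has a number. Also open, on these data alone, is how a morpholine, a piperazine or a benzylamino group at this position would read, and whether any of them would give a lower number than the (3,4-dimethylphenyl)amino group.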